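Hydroxypyridinyl in place of methoxyphenyl on the imidazole nitrogen

This account rests on a few compounds, and the source may have more. Where it says the series, first, only, none or still open, it means among the compounds named here.

Compound 1, `COc1ccc(-n2cnc3cnc(-c4ccc(F)cc4C)cc32)cc1`: 6 nM
Compound 2, `COc1ccc(-n2cnc3cnc(-c4ccc(F)cc4C)cc32)cc1Cl`: 21 nM
Compound 3, `COc1ccc(-n2cnc3cnc(-c4ccc(F)cc4C)cc32)cc1C`: 14 nM

In a functional assay on HL-60 cells (Homo sapiens) for activation, read by flow cytometry, with a stated time of 4 days (a lower number here means that less compound is needed, a higher number that more compound is needed for the effect), compound 1 stands lowest of the three numbers; the nearest is compound 3 and the furthest compound 2. Compound 4, `Cc1cc(F)ccc1-c1cc2c(cn1)ncn2-c1ccc(O)nc1`, differs from compound 1 in one place: 6-hydroxypyridin-3-yl in place of 4-methoxyphenyl on an aromatic nitrogen. The measured steps bear on this only loosely, since each adds a group to the same ring rather than replacing it: a 3.5-fold higher number from compound 1 to compound 2 (0.54 log units; beyond the scatter) and a 2.3-fold higher number from compound 1 to compound 3 (0.37 log units; beyond the scatter). Both were modest rises, and compound 3 against compound 2 lies within the scatter. A ring swap that also brings in a hydrogen-bond donor is a larger change than either, so a modest to moderate rise is expected. Compound 4 is therefore estimated at 20 nM, between 4 nM and 120 nM, which would mean a 3.3-fold higher number from compound 1 to compound 4 (0.52 log units; beyond the scatter).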

Compound 4, half-maximal effective concentration: > 10000 nM
Compound 4: a limit, no number; the forecaster's own chance of this, stated with the estimate: 5%; middle value at least 500-fold (2.69 log units) away from the limit.
By their numbers in this assay, from the lowest: compound 1; then compounds 3 and 2 (each within the scatter of the next). At a limit, above all of these: compound 4.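

In this assay, replacing the whole ring on this aromatic nitrogen gives an at least 1600-fold higher number from compound 1 to compound 4 (3.22 log units; beyond the scatter), a far larger step than the modest 3.5-fold higher number from compound 1 to compound 2 (0.54 log units; beyond the scatter). So this position, which kept measurable numbers when chloro or methyl was added to the 4-methoxyphenyl ring, does not accept every aromatic ring. Compound 4 stands at a limit, not a number: the limit of > 10000 nM in this assay, at which 1 of the 4 values shown sits.

The step changes the ring nitrogen and the hydroxyl together, so the compounds shown cannot separate the two. Within the data shown here, a 4-hydroxyphenyl or a 6-methoxypyridin-3-yl group on the same nitrogen would each carry only one of these changes.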